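The source may hold more compounds than are shown below. What is called first, only, known or untested is meant among the compounds shown, and "the series" means these compounds.

Working notes on the decyl and hexyl phosphate thiocarbamates.

Compound 1 `CCCCCCCCCCOP(=O)(O)OCCSC(=S)N1CCCC1` and compound 2 `CCCCCCCCCCOP(=O)(O)OCCSC(=S)N1CCCCC1` share the decyl chain on the phosphate, and compound 3 `CCCCCCOP(=O)(O)OCCSC(=S)N1CCCC1` carries the hexyl chain. In a functional assay on PC-3 cells (Homo sapiens) for inhibition, read by MTT assay, with stated times of 18 h and 4 h (on this read-out higher numbers stand for weaker inhibition and lower numbers for stronger inhibition), compound 1 gives 56100 nM and compound 2 gives 62500 nM. The step of a 1.1-fold higher number from compound 1 to compound 2 (0.05 log units; within the scatter) comes from the change (piperidin-1-yl in place of pyrrolidin-1-yl on a thiocarbonyl carbon). For compound 3 in this assay only a limit is recorded, > 100000 nM, so the step of an at least 1.7-fold higher number from compound 1 to compound 3 (0.25 log units; that floor lies within the scatter) is read against that limit, which is where the limit of > 100000 nM in this assay, at which 1 of the 3 values shown sits, is reached; the change behind it is hydrogen in place of butyl on a saturated chain carbon, six bonds along the chain from an oxygen on an unsaturated carbon, and that is also how the core of compound 3 differs from the core of compound 1.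

Compound 4 `CCCCCCOP(=O)(O)OCCSC(=S)N1CCCCC1` is not yet measured in this assay. It stands to compound 3 as compound 2 stands to compound 1: the change piperidin-1-yl in place of pyrrolidin-1-yl on a thiocarbonyl carbon is the same change, made at the same place, a thiocarbonyl carbon whose other neighbour is sulfur. Among the measured compounds shown here, the one measured instance of it, a 1.1-fold higher number from compound 1 to compound 2 (0.05 log units; within the scatter), sits within the scatter. With compound 3 already at the limit, the expected step that the limit leaves unreadable from compound 3 to compound 4 is small and compound 4 is expected to remain at or past the limit as well. For compound 4 the estimate in this assay is 130000 nM, expected between 70000 nM and 300000 nM, and most likely only a limit will be reported.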

Compound 4, half-maximal inhibitory concentration: > 100000 nM
Compound 4 ended at the assay's limit; the forecaster's own chance of this, stated with the estimate: 80%; the middle value does not contradict the limit.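

On the core of compound 2, hydrogen in place of butyl on a saturated chain carbon, six bonds along the chain from an oxygen on an unsaturated carbon, gives in this assay an at least 1.6-fold higher number from compound 2 to compound 4 (0.20 log units; that floor lies within the scatter), and set beside the same change on the core of compound 1, the two steps read: the same change on two cores in this assay, an at least 1.7-fold higher number (0.25 log units; that floor lies within the scatter) from compound 1 to compound 3 and an at least 1.6-fold higher number (0.20 log units; that floor lies within the scatter) from compound 2 to compound 4; the limit leaves it open whether they differ. This shows that the change takes both the core of compound 1 and the core of compound 2 to the same limit, but it does not show that the change has the same size on the two cores, nor that either step goes beyond the scatter. The step from compound 3 to compound 4 cannot be read, since the entries for both hexyl compounds are limits and not numbers, and the series stands at that limit for these entries: the limit of > 100000 nM in this assay, at which 2 of the 4 values shown sit.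

The compounds shown leave open where an octyl chain on the phosphate would fall in this series, and whether a dodecyl chain would give a number clearly apart from those of the decyl compounds. They also leave open whether a morpholin-4-yl group on the thiocarbonyl carbon would read differently from the pyrrolidin-1-yl and piperidin-1-yl groups.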